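Acetyl in place of methyl: compound 3 to compound 4

A few compounds are considered here, and "the series" means these few. Any claim that something is new, unique, unknown or untested is made for them only; others in the source may bear on it.

Values in a functional assay on DLD-1 cells (Homo sapiens) for inhibition, read by luminescence, with a stated time of 3 days (on this read-out lower numbers stand for stronger inhibition of growth and higher numbers for weaker inhibition of growth), for the measured compounds:
- compound 1 `CC[C@@H]1CC[C@@H](C(=O)N2CCOCC2)N1C(=O)C1=C(C(C)C)N2C(=N[C@@](C)(c3ccc(Cl)cc3)[C@H]2c2ccc(Cl)cc2)S1` gives 4200 nM
- compound 2 `CC[C@@H]1CC[C@@H](C(=O)N2CCN(C)[C@H](C)C2)N1C(=O)C1=C(C(C)C)N2C(=N[C@@](C)(c3ccc(Cl)cc3)[C@H]2c2ccc(Cl)cc2)S1` gives 3600 nM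
- compound 3 `CC[C@@H]1CC[C@@H](C(=O)N2CCN(C)[C@@H](C)C2)N1C(=O)C1=C(C(C)C)N2C(=N[C@@](C)(c3ccc(Cl)cc3)[C@H]2c2ccc(Cl)cc2)S1` gives 3900 nM

Compound 3 at 3900 nM stands within the scatter of both other values, and the steps of a 1.1-fold lower number from compound 1 to compound 3 (0.03 log units; within the scatter) and a 1.1-fold higher number from compound 2 to compound 3 (0.03 log units; within the scatter) show this directly.

Compound 4 `CC[C@@H]1CC[C@@H](C(=O)N2CCN(C(C)=O)[C@@H](C)C2)N1C(=O)C1=C(C(C)C)N2C(=N[C@@](C)(c3ccc(Cl)cc3)[C@H]2c2ccc(Cl)cc2)S1` is not yet measured. It carries acetyl in place of methyl on an amine nitrogen in a ring, counted as acetyl in place of methyl on an amine nitrogen in a ring and placed three ring bonds from the ring nitrogen.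

Within the data shown here, no measured compound bears acetyl at this place, so the evidence is indirect. The closest steps exchange morpholin-4-yl for 3,4-dimethylpiperazin-1-yl on a carbonyl carbon. Both a 1.2-fold lower number from compound 1 to compound 2 (0.07 log units; within the scatter) and a 1.1-fold lower number from compound 1 to compound 3 (0.03 log units; within the scatter) stay within the scatter. The change of configuration in a 1.1-fold higher number from compound 2 to compound 3 (0.03 log units; within the scatter) does the same, and it comes with the fact that compounds 2 and 3 differ only in the configuration as drawn as its only distinction.

With compound 3 at 3900 nM and the step of a 1.1-fold lower number from compound 1 to compound 3 (0.03 log units; within the scatter) as the guide, no step beyond the scatter is expected in this assay in either direction. The expected change is a 1.2-fold higher number from compound 3 to compound 4 (0.06 log units; within the scatter) and would remain a small one. The estimate for compound 4 is 4500 nM with an expected range from 2200 nM to 9000 nM on this read-out.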

Compound 4, concentration for 50% growth inhibition in the DLD-1 assay: 2600 nM
Estimate against measurement, compound 4: 1.7-fold (0.24 log units) above; the measured number falls inside the stated range.
By their numbers in the DLD-1 assay, from the lowest: compounds 4, 2, 3 and 1 (each within the scatter of the next).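

Acetyl is accepted on this amine nitrogen in a ring without a step beyond the scatter in the DLD-1 assay, where compound 4 gives 2600 nM: a 1.5-fold lower number from compound 3 to compound 4 (0.18 log units; within the scatter) is the first reading at this place with a carbonyl-bearing group instead of methyl. Among these compounds, the wider exchanges on the carbonyl carbon read the same way, as both a 1.4-fold lower number from compound 2 to compound 4 (0.14 log units; within the scatter) and a 1.6-fold lower number from compound 1 to compound 4 (0.21 log units; within the scatter) stay within the scatter, so all four compounds so far sit in one band and the piperazine nitrogen substituent has not yet separated any of them. In a physicochemical assay for solubility, read by HPLC, in phosphate buffer, at pH 6.8 (on this read-out lower numbers stand for lower solubility and higher numbers for higher solubility), compound 3 gives 16 ug/mL and compound 4 gives 24 ug/mL, so the same change also stays within the scatter with a 1.5-fold higher number from compound 3 to compound 4 (0.18 log units; within the scatter), and nothing given here accounts for the size of any of these steps.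

Going by these compounds, whether the configuration at the ring carbon bearing the methyl group matters once acetyl is on the nitrogen stays open, since only the methyl pair of compound 2 and compound 3 offers that comparison. Also open, on these data alone, is whether methanesulfonyl, a longer acyl chain such as propanoyl, or a carboxylic acid on this nitrogen would move either read-out beyond the scatter.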